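Amide ring variation on the shared core

The compounds below may be only part of what the source reports. "The series", "measured", "known", "first", "only" and "open" are said of these compounds alone.

For the measured compounds named here, compound 2 `CC1CCCC(C(=O)N2CCc3nc(C#Cc4ccccc4)sc3C2)C1` holds the highest of the two numbers measured so far in an assay on HEK293 cells for positive allosteric modulation of metabotropic glutamate receptor 5 (Homo sapiens), read by FLIPR, with a stated time of 1 h; on this read-out lower numbers stand for an effect already at smaller amounts and higher numbers for an effect only at larger amounts of compound: compound 2 gives 100 nM. Going by the values given here, its nearest neighbour is compound 1 `O=C(C1CCCC1)N1CCc2nc(C#Cc3ccccc3)sc2C1`, which in this assay gives 19 nM; the step of a 5.3-fold higher number from compound 1 to compound 2 (0.72 log units; beyond the scatter) is the only measured step. Compound 3 `O=C(C1CCCCO1)N1CCc2nc(C#Cc3ccccc3)sc2C1` is not yet measured. It differs from compound 2 by oxan-2-yl in place of 3-methylcyclohexyl on a carbonyl carbon. Among the compounds with values here, the single measured step bears on it only loosely: that step changed the carbocycle on the carbonyl carbon, whereas here an oxan-2-yl enters and the 3-methylcyclohexyl leaves, so no direct precedent exists. A return toward the number of compound 1 is possible, but no step beyond the scatter is firmly expected, and the estimated step is a 1.7-fold lower number from compound 2 to compound 3 (0.22 log units; within the scatter). Compound 3 is expected in this assay to give about 60 nM, with a range from 15 nM to 250 nM.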

Compound 3, half-maximal effective concentration: 320 nM
The estimate for compound 3 lay 5.3-fold (0.73 log units) below the measured number, and the stated range ends below it.
By their numbers in this assay, from the lowest: compound 1; then compound 2; then compound 3.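

Notes on the carbonyl substituent: in this assay the change to oxan-2-yl on the carbonyl carbon brings a 3.2-fold higher number from compound 2 to compound 3 (0.51 log units; beyond the scatter) and also a 17-fold higher number from compound 1 to compound 3 (1.23 log units; beyond the scatter) as the largest step in the series so far. The earlier step compared carbocycles only, whereas this result shows that, among the three compounds, the one ring with a hetero atom and a hydrogen-bond acceptor gives the highest number, and neither carbocyclic compound goes against this. No supporting measurement accounts for the rise.

Compound 3 differs from compound 2 both in the ring oxygen and in the missing methyl, so the compounds shown do not separate these two changes. From the compounds shown here alone, whether a plain cyclohexyl, an oxan-4-yl or a piperidine ring on the carbonyl carbon would fall nearer compound 1 or compound 3 remains open.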